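A few compounds are considered here, and "the series" means these few. Any claim that something is new, unique, unknown or untested is made for them only; others in the source may bear on it.

Working notes on the series, all read in a functional assay on MV4-11 cells (Homo sapiens) for inhibition, read by resazurin assay, with a stated time of 72 h; a higher number here means a weaker inhibitor of growth, a lower number a stronger inhibitor of growth. Compound 1 (`O=C1NCCC12CCN(c1c(Cl)cncc1-c1ccco1)CC2`) gives 940 nM and compound 2 (`O=C1NCCC12CCN(c1c(Cl)cncc1-c1ccoc1)CC2`) gives 750 nM. Compound 3 (`Cc1ccc(-c2cncc(Cl)c2N2CCC3(CCNC3=O)CC2)o1`) gives 4950 nM, the highest number of the three and the weakest member, its steps to both others lying beyond the scatter.

Compound 4 (`O=C1NCCC12CCN(c1c(Cl)cncc1-c1ccc(Cl)s1)CC2`) carries 5-chlorothiophen-2-yl in place of 5-methylfuran-2-yl on an aromatic carbon. Within the data shown here, three measured steps bear on this. Moving between the two unsubstituted furans changed little (a 1.3-fold lower number from compound 1 to compound 2 (0.10 log units; within the scatter)), whereas the methyl group gave larger steps (a 5.3-fold higher number from compound 1 to compound 3 (0.72 log units; beyond the scatter) and a 6.6-fold higher number from compound 2 to compound 3 (0.82 log units; beyond the scatter)). Among the measured compounds shown here, no measured compound holds a thiophene or a chlorine on the five-membered ring, so these steps only loosely guide the swap. Compound 4 keeps a substituted five-membered ring, as compound 3 does (4950 nM), so a value near compound 3 is expected, with no step beyond the scatter in this assay. The expected change is small (a 1.4-fold lower number from compound 3 to compound 4 (0.15 log units; within the scatter)). The estimate for compound 4 is 3500 nM (expected range 1200 nM to 9000 nM).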

Compound 4, concentration for 50% growth inhibition: 560 nM
For compound 4 the middle estimate is 6.3-fold (0.80 log units) above the measured one; measured number outside the range, below it.
By their numbers in this assay, from the lowest: compounds 4, 2 and 1 (each within the scatter of the next); then compound 3.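

At this aromatic carbon, ortho to a large group, a substituted five-membered ring does not of itself bring the loss seen with 5-methylfuran-2-yl: in this assay the swap to 5-chlorothiophen-2-yl gives an 8.8-fold lower number from compound 3 to compound 4 (0.95 log units; beyond the scatter), a step beyond the scatter. The same group stands within the scatter of both unsubstituted furans, with a 1.3-fold lower number from compound 2 to compound 4 (0.13 log units; within the scatter) and a 1.7-fold lower number from compound 1 to compound 4 (0.22 log units; within the scatter), so among these compounds only compound 3 reads apart. Nothing measured on these groups speaks to the origin of the step.

The swap changes the ring hetero atom and the substituent together, and the compounds shown do not separate the two; 5-methylthiophen-2-yl and 5-chlorofuran-2-yl would. Also open, going by these compounds, is how an amine or a carboxylic acid would read on the five-membered ring at this place.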